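Swapping One Aryl Group on a Shared Core

A few compounds are considered here, and "the series" means these few. Any claim that something is new, unique, unknown or untested is made for them only; others in the source may bear on it.

In a physicochemical assay for solubility (on this read-out lower numbers stand for lower solubility and higher numbers for higher solubility), compound 1 (`COc1ccc(-n2cnc3cnc(-c4ccccc4)cc32)cc1OC`) gives 28000 nM. Compound 2 (`COc1cc(F)ccc1-c1cc2c(cn1)ncn2-c1ccc(OC(F)F)cc1`) gives 3000 nM, the lower of the two numbers, and the gap between them lies beyond the usual scatter, meaning the spread seen when a measurement is repeated.

Compound 3 (`Cc1cc(F)c(F)cc1-c1cc2c(cn1)ncn2-c1ccc(OC(F)F)cc1`) has not been measured yet. It carries 4,5-difluoro-2-methylphenyl in place of the 4-fluoro-2-methoxyphenyl of compound 2, on an aromatic carbon of the shared core: 4,5-difluoro-2-methylphenyl in place of 4-fluoro-2-methoxyphenyl on an aromatic carbon. The group changes, but its place on the core does not.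

For the measured compounds named here, no two measured compounds differ in one place only, so the data hold no direct precedent for a change like this one. The natural starting point is compound 2 at 3000 nM, and only a cautious forecast in this assay is possible. The expected step is a 1.5-fold lower number from compound 2 to compound 3 (0.18 log units; within the scatter), a small downward move that would stay within the scatter. Compound 3 is expected at 2000 nM, with an estimated range of 500 nM to 8000 nM.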

Compound 3, solubility: 15000 nM
Compound 3: the middle estimate sits 7.5-fold (0.88 log units) below what was measured; measured number outside the range, above it.
By their numbers in this assay, from the lowest: compound 2; then compounds 3 and 1 (each within the scatter of the next).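

In this assay, for the compounds shown here, the aryl group on this aromatic carbon of the shared core clearly matters: 4,5-difluoro-2-methylphenyl in place of 4-fluoro-2-methoxyphenyl gives a 5.0-fold higher number from compound 2 to compound 3 (0.70 log units; beyond the scatter), the first change in this set that can be read at a single place. Going by these compounds alone, the two groups have the same number of heavy atoms and the same kind of carbon-only aromatic ring, but the hydrogen-bond acceptor counted in the group that leaves has no counterpart in the group that enters, so even a swap of equal size can go with a clear shift in the read-out. No separate measurement here shows why the number rises between these two compounds.

The swap replaces methoxy with methyl and also adds a second fluorine, so these compounds cannot show how much of the step belongs to each of those two differences. From the compounds shown here alone, it also remains open how the number would respond on this same ring to a group of a different kind, such as a dimethylamino group or a carboxylic acid.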